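The source may report more compounds than this note shows. Statements on the series, on what has been measured and on what is new or still open speak of the compounds shown alone.

Compound 1 `Cn1nnc(O)c1C(=O)Nc1cc(C(F)(F)F)cc(C(F)(F)F)c1`: in an assay on isolated protein for inhibition of mitogen-activated protein kinase kinase kinase 14 (Homo sapiens), read by ADP-Glo, with a stated time of 60 min, tested at 100 uM, in the presence of a further agent that is not named here (on this read-out higher numbers stand for more inhibition at the one concentration tested (going by the name of the read-out) and lower numbers for less inhibition), compound 1 gives 12.1%
Compound 2 `O=C(Nc1cc(C(F)(F)F)cc(C(F)(F)F)c1)c1n[nH]nc1O`: in this assay compound 2 gives -9.5%

Going by the values given here, compound 2 stands lowest of the two numbers so far, with compound 1 as its only neighbour, reached by a number 21.6 percentage points lower from compound 1 to compound 2 (beyond the scatter). Compound 3 `Nc1nonc1C(=O)Nc1cc(C(F)(F)F)cc(C(F)(F)F)c1` is not yet measured; it differs from compound 2 by 4-amino-1,2,5-oxadiazol-3-yl in place of 5-hydroxy-2H-1,2,3-triazol-4-yl on a carbonyl carbon. Among the compounds with values here, the one measured step also reworked the ring on the carbonyl carbon and shifted the read-out only modestly, and both measured numbers sit low. A step of similar small size is therefore expected for compound 3, a number 12.5 percentage points higher from compound 2 to compound 3 (beyond the scatter). Compound 3 is estimated at 3%, with a range from -15% to 22%.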

Compound 3, a percentage reported as inhibition, at one concentration (the size of the read-out at that concentration, not a potency): -9.2%
For compound 3 the middle estimate is 12.2 percentage points above the measured one; measured number inside the range.
By their numbers in this assay, from the lowest: compounds 2 and 3 (each within the scatter of the next); then compound 1.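

In this assay, 4-amino-1,2,5-oxadiazol-3-yl in place of 5-hydroxy-2H-1,2,3-triazol-4-yl on the carbonyl carbon gives a number 0.3 percentage points higher from compound 2 to compound 3 (within the scatter), so these two different rings, with their different donor and acceptor counts, cannot be told apart here. The same new ring in place of 4-hydroxy-1-methyl-1H-1,2,3-triazol-5-yl gives a number 21.3 percentage points lower from compound 1 to compound 3 (beyond the scatter), so compound 1 stands apart from both other compounds. Nothing measured here bears on the reason for this result.

From the compounds shown here alone, whether a carboxylic acid or a simple amine on that carbonyl carbon would read differently stays open.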